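From 3-(trifluoromethyl)phenyl to 4-sulfamoylphenyl on the amide

The source may hold more compounds than are shown below. What is called first, only, known or untested is meant among the compounds shown, and "the series" means these compounds.

In an ADME assay on MT4 cells (Homo sapiens) for cytotoxicity, read by MTT assay, with a stated time of 5 days (a higher number here means that more compound is tolerated, a lower number that less compound is tolerated), compound 1 `COc1cc2nc([S+]([O-])CC(=O)Nc3ccc([N+](=O)[O-])cc3)nc(Nc3c(Cl)cc(/C=C/C#N)cc3Cl)c2cc1OC` gives 92800 nM and compound 2 `COc1cc2nc([S+]([O-])CC(=O)Nc3cccc(Cl)c3)nc(Nc3c(Cl)cc(/C=C/C#N)cc3Cl)c2cc1OC` gives 68900 nM. Compound 3 `COc1cc2nc([S+]([O-])CC(=O)Nc3cccc(C(F)(F)F)c3)nc(Nc3c(Cl)cc(/C=C/C#N)cc3Cl)c2cc1OC` has the lowest number of the three, at 21800 nM. Compound 4 `COc1cc2nc([S+]([O-])CC(=O)Nc3ccc(S(N)(=O)=O)cc3)nc(Nc3c(Cl)cc(/C=C/C#N)cc3Cl)c2cc1OC` puts 4-sulfamoylphenyl in place of 3-(trifluoromethyl)phenyl on an amide-type nitrogen. Two measured steps replace other groups at this place with 3-(trifluoromethyl)phenyl, and both are modest: a 4.3-fold lower number from compound 1 to compound 3 (0.63 log units; beyond the scatter), and a 3.2-fold lower number from compound 2 to compound 3 (0.50 log units; beyond the scatter). By contrast, a 1.3-fold lower number from compound 1 to compound 2 (0.13 log units; within the scatter). Among the compounds with values here, no compound with 4-sulfamoylphenyl has been measured, so a modest rise is expected on leaving 3-(trifluoromethyl)phenyl, with real uncertainty. The expected step is a 2.8-fold higher number from compound 3 to compound 4 (0.44 log units; beyond the scatter). For compound 4 the estimate is 60000 nM, with a range of 22000 nM to 150000 nM.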

Compound 4, half-maximal cytotoxic concentration: > 189000 nM
Compound 4: only a limit was reported (the forecaster's own chance of this, stated with the estimate: 25%); middle value at least 3.1-fold (0.49 log units) from the limit.
By their numbers in this assay, from the lowest: compound 3; then compounds 2 and 1 (each within the scatter of the next). At a limit, above all of these: compound 4.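

In this assay compound 4 gives a limit and not a number: the limit of > 189000 nM in this assay, at which 1 of the 4 values shown sits.

Even so, this place on the amide-type nitrogen can clearly carry a group that lifts the number: 4-sulfamoylphenyl gives an at least 8.6-fold higher number from compound 3 to compound 4 (0.93 log units; beyond the scatter) and an at least 2.7-fold higher number from compound 2 to compound 4 (0.43 log units; beyond the scatter) as well. The remaining step, an at least 2.0-fold higher number from compound 1 to compound 4 (0.30 log units; that floor lies within the scatter) here, does not set sulfamoyl apart from nitro, so those two groups cannot be ordered.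

As far as these compounds go, the true number for compound 4 stays open. So does what a 4-aminophenyl or 4-carboxyphenyl group would give on the same amide.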